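The source may report more compounds than this note shows. Statements on the series, on what has been measured and on what is new or still open speak of the compounds shown alone.

Of the compounds shown here, three have so far been measured in an ADME assay on a cell-free system (plasma, Homo sapiens) for metabolic stability (a lower number here means that the compound disappears faster, a higher number that the compound lasts longer), all sharing one core and differing only in the group on the aromatic carbon. Compound 1 `CCOC(=O)c1ccc(/N=N/N(C)C(=O)OCOC(C)=O)cc1` gives 0.2 h. Compound 2 `CC(=O)OCOC(=O)N(C)/N=N/c1ccc(C#N)cc1` gives 0.117 h, and compound 3 `CC(=O)OCOC(=O)N(C)/N=N/c1ccc(C)cc1` gives 0.25 h. Among these three numbers that of compound 1 is the second highest, although its gaps to both neighbours are within the scatter: a 1.7-fold lower number from compound 1 to compound 2 (0.23 log units; within the scatter), and a 1.3-fold higher number from compound 1 to compound 3 (0.10 log units; within the scatter). For the measured compounds named here, the only step beyond the scatter is the one in which a 2.1-fold higher number from compound 2 to compound 3 (0.33 log units; beyond the scatter).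

Compound 4 `CCOC(=O)c1ccc(/N=N/N(C)C(=O)OCOC(=O)c2ccccc2O)cc1` differs from compound 1 at a different place: 2-hydroxyphenyl in place of methyl on a carbonyl carbon. Going by the values given here, none of the measured steps touches this carbonyl carbon; each of them alters only the group on the aromatic carbon, so no measured step bears directly on the change at hand, and the numbers give no direction for it. The expectation for compound 4 is therefore a result within the scatter of compound 1, a 1.3-fold higher number from compound 1 to compound 4 (0.10 log units; within the scatter). Compound 4 is estimated at 0.25 h, with a range from 0.1 h to 0.6 h.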

Compound 4, half-life: 0.567 h
Estimate against measurement, compound 4: 2.3-fold (0.36 log units) below, and the stated range covers the measured number.
By their numbers in this assay, from the lowest: compounds 2, 1 and 3 (each within the scatter of the next, the first and the last beyond it); then compound 4.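

The carbonyl carbon at the acetyl end of compound 1 now proves to be a place where a change can shift the half-life in this assay: 2-hydroxyphenyl in place of methyl gives a 2.8-fold higher number from compound 1 to compound 4 (0.45 log units; beyond the scatter) and so moves the number beyond the scatter. For the compounds shown here, the earlier steps all altered the group on the aromatic carbon, so this is the first reading of any kind at this carbonyl carbon, and its direction is towards a compound that lasts longer. Nothing in the available data explains why the number rises here.

This single change brings in a ring and a hydroxy group together, so a plain phenyl, a 2-aminophenyl or a longer chain on this carbonyl carbon would be needed to tell their shares apart. On these data alone, it also remains open whether the same change raises the number when cyano or methyl sits on the aromatic carbon.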